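The compounds below may be only part of what the source reports. "The series", "measured", "known", "first", "only" and "open" are said of these compounds alone.

Working notes on the series.

Of the compounds shown here, three have been measured in an assay on Sf9 cells for inhibition of sphingosine-1-phosphate lyase 1 (Homo sapiens), with a stated time of 1 h; a lower number here means a stronger inhibitor, a higher number a weaker inhibitor. Compound 1 `C[C@@H]1CN(c2nnc(Cc3ccccc3)c3cc(Cl)ccc23)CCN1c1ccc(C#N)cn1` gives 2300 nM. Compound 2 `C[C@@H]1CN(c2nnc(Cc3ccccc3)c3ccc(Cl)cc23)CCN1c1ccc(C#N)cn1` gives 210 nM, the lowest of the three numbers. Compound 3 `C[C@@H]1CN(c2nnc(Cc3ccccc3)c3cc(C(F)(F)F)ccc23)CCN1c1ccc(C#N)cn1` gives 12000 nM. The difference between the cores of compound 1 and compound 2 is not broken down here; their two values show compound 2 with the stronger inhibition.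

One structural change is seen twice. From compound 1 to compound 3 it is trifluoromethyl in place of chloro on an aromatic carbon and it produced a 5.2-fold higher number from compound 1 to compound 3 (0.72 log units; beyond the scatter). The same change, (trifluoromethyl in place of chloro on an aromatic carbon), leads from compound 2 to the unmeasured compound 4 `C[C@@H]1CN(c2nnc(Cc3ccccc3)c3ccc(C(F)(F)F)cc23)CCN1c1ccc(C#N)cn1`.

Going by the values given here, for compound 4 a similar step is expected, since the only precedent, a 5.2-fold higher number from compound 1 to compound 3 (0.72 log units; beyond the scatter), is a modest weakening. The step from compound 2 to compound 4 in this assay is estimated at a 5.2-fold higher number from compound 2 to compound 4 (0.72 log units; beyond the scatter). The expected value for compound 4 in this assay is 1100 nM, with a range of 400 nM to 3500 nM; this rests on a single precedent and is uncertain.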

Compound 4, half-maximal inhibitory concentration: 100 nM
Estimate against measurement, compound 4: 11-fold (1.04 log units) above; the whole stated range lies above it.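

On the core of compound 2, trifluoromethyl in place of chloro on an aromatic carbon gives a 2.1-fold lower number from compound 2 to compound 4 (0.32 log units; beyond the scatter), so the change does not keep the direction it has on the core of compound 1. In this assay the two steps therefore cannot be treated as one transferable step: the same change on two cores in this assay, a 5.2-fold higher number (0.72 log units; beyond the scatter) from compound 1 to compound 3 and a 2.1-fold lower number (0.32 log units; beyond the scatter) from compound 2 to compound 4, 11-fold (1.04 log units) apart, beyond the scatter of two such steps

Going by these compounds alone, this shows that, in this series, the step seen on one core cannot simply be carried over to the other, although it rests on only one pair per core and gives no general rule for the change or any reason why the cores differ.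

The compounds shown leave open how each core responds to another group on that aromatic carbon, such as methoxy or an amine, and whether the two cores would diverge in the same way with such a group. They also leave open how either core behaves with only hydrogen on that carbon, which would give both chloro and trifluoromethyl a common reference.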